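Lengthening the Linker: From Compound 3 to Compound 4

The source may hold more compounds than are shown below. What is called first, only, known or untested is meant among the compounds shown, and "the series" means these compounds.

Measured so far in an assay on isolated protein for inhibition of histone deacetylase 8 (Homo sapiens); on this read-out higher numbers stand for weaker inhibition and lower numbers for stronger inhibition:
Compound 1, `O=C(CCCCCC(=O)c1ccccc1)NO`, gives 1500 nM.
Compound 2, `O=C(CCCCCCC(=O)c1ccccc1)NO`, gives 500 nM.
Compound 3, `O=C(CCCCCCCC(=O)c1ccccc1)NO`, gives 65 nM.

Among these three, compound 3 has the lowest number in this assay, and its distance to each of the other two is beyond the scatter, so within this small set it is the strongest inhibitor. Compound 4, `O=C(CCCCCCCCC(=O)c1ccccc1)NO`, has not yet been measured. It differs from compound 3 by a single change: (hydroxycarbamoyl)methyl in place of hydroxycarbamoyl on a saturated chain carbon, seven bonds along the chain from a carbonyl carbon. The same kind of lengthening by one chain carbon has been seen twice already: a 3.0-fold lower number from compound 1 to compound 2 (0.48 log units; beyond the scatter) and a 7.7-fold lower number from compound 2 to compound 3 (0.89 log units; beyond the scatter). Taken together, a 23-fold lower number from compound 1 to compound 3 (1.36 log units; beyond the scatter). Because a 7.7-fold lower number from compound 2 to compound 3 (0.89 log units; beyond the scatter) and a 3.0-fold lower number from compound 1 to compound 2 (0.48 log units; beyond the scatter) both point the same way and both lie beyond the scatter, a further lowering of the number is expected for compound 4, though two steps give no assurance that the gain continues rather than levelling off. The expected step is a 1.6-fold lower number from compound 3 to compound 4 (0.21 log units; within the scatter). For compound 4 the estimate is 40 nM, with a range from 10 nM to 200 nM.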

Compound 4, half-maximal inhibitory concentration: 135 nM
For compound 4 the middle estimate is 3.4-fold (0.53 log units) below the measured one; low and high end bracket the measured number.
By their numbers in this assay, from the lowest: compound 3; then compound 4; then compound 2; then compound 1.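

Lengthening the chain does not keep helping at this position: in this assay the trend reverses (a 2.1-fold higher number from compound 3 to compound 4 (0.32 log units; beyond the scatter)), which leaves compound 3 with the lowest number of the four. Compound 4 nevertheless keeps part of the gain made along the series (a 3.7-fold lower number from compound 2 to compound 4 (0.57 log units; beyond the scatter)), so the reversal does not take the number back to where the shorter chains stood. The effect of adding one chain carbon therefore depends on the chain that receives it, and the same change cannot be assumed to give the same result at each length: (the same change on two cores in this assay, a 3.0-fold lower number (0.48 log units; beyond the scatter) from compound 1 to compound 2 and a 2.1-fold higher number (0.32 log units; beyond the scatter) from compound 3 to compound 4, 6.2-fold (0.79 log units) apart, beyond the scatter of two such steps).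

The compounds shown leave open whether a longer chain would raise the number further or level off. They also leave open whether the same preferred length would hold with a carboxylic acid in place of hydroxycarbamoyl.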